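Replacing tert-butyl with bromo on the aromatic ring

This account rests on a few compounds, and the source may have more. Where it says the series, first, only, none or still open, it means among the compounds named here.

In an ADME assay on TERT-RPE1 cells (Homo sapiens) for cytotoxicity, read by MTT assay, with a stated time of 72 h (on this read-out higher numbers stand for weaker inhibition and lower numbers for stronger inhibition), compound 3 `COc1ccc(/C=C2\S/C(=N\c3ccc(C(C)(C)C)cc3)N(C)C2=O)cc1` gives 46700 nM, the higher of the two true numbers in the series, while compound 2 `COc1ccc(/C=C2\S/C(=N\c3ccc(C)c(Cl)c3)N(C)C2=O)cc1` gives 23000 nM. Compound 1 `COc1ccc(/C=C2\S/C(=N\c3ccc(Cl)cc3)N(C)C2=O)cc1` gives > 100000 nM, which is a limit of the assay and not a number.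

Compound 4 `COc1ccc(/C=C2\S/C(=N\c3ccc(Br)cc3)N(C)C2=O)cc1` has bromo in place of tert-butyl on an aromatic carbon. Among the compounds with values here, the closest precedent is tert-butyl in place of chloro at that carbon, an at least 2.1-fold lower number from compound 1 to compound 3 (0.33 log units; beyond the scatter), and the change here runs the opposite way, with bromo rather than chloro. The other measured step, an at least 4.3-fold lower number from compound 1 to compound 2 (0.63 log units; beyond the scatter), is a different change and bears less directly.

A modestly higher number is therefore expected, a 1.9-fold higher number from compound 3 to compound 4 (0.28 log units; within the scatter). Compound 4 is estimated at 90000 nM, with an expected range of 40000 nM to 200000 nM.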

Compound 4, half-maximal inhibitory concentration: > 100000 nM
Compound 4 gave a limit, no number (the forecaster's own chance of this, stated with the estimate: 45%); middle value at least 1.1-fold (0.04 log units) from the limit.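

In this assay, swapping the tert-butyl for bromo gives an at least 2.1-fold higher number from compound 3 to compound 4 (0.33 log units; beyond the scatter), and 4-bromophenyl in place of 3-chloro-4-methylphenyl gives an at least 4.3-fold higher number from compound 2 to compound 4 (0.63 log units; beyond the scatter). Compound 4 reads as a limit of the assay and not a number, so these steps fix a direction and a minimum size only. The step between chloro and bromo cannot be read, and compound 1 and compound 4 stay unseparated: the limit of > 100000 nM in this assay, at which 2 of the 4 values shown sit.

Open, from the compounds shown here alone, are a true number for bromo or chloro at this carbon and the reading of an amine or a carboxylic acid there.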